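Swapping a thiourea tail for a cyanoguanidine tail

This account rests on a few compounds, and the source may have more. Where it says the series, first, only, none or still open, it means among the compounds named here.

Measured so far:
- compound 1, `N#CNC(=N)NCCCCCn1nc(-c2ccccc2)ccc1=O`: 31%
- compound 2, `C/N=C(\S)NCCCCCn1nc(-c2ccccc2)ccc1=O`: 68.9%
- compound 3, `C/N=C(\S)N(C)CCCCn1nc(-c2ccccc2)ccc1=O`: 17.5%

All three share one core and differ only in the chain that hangs from it. In a functional assay on the whole organism with Rattus norvegicus as the target, at a dose of 100 mg/kg (a lower number here means less inhibition, a higher number more inhibition at the dose given (going by the name of the read-out)), compound 3 gives 17.5%, the lowest of the three numbers; the nearest is compound 1, and the step of a number 13.5 percentage points lower from compound 1 to compound 3 (beyond the scatter) lies beyond the scatter, while the gap to compound 2, a number 51.4 percentage points lower from compound 2 to compound 3 (beyond the scatter), is large.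

Compound 4, `CN(C)/C(=N/CCCn1nc(-c2ccccc2)ccc1=O)NC#N`, has not yet been measured. Relative to compound 3, the change is a group of 8 heavy atoms (4 carbon, 4 nitrogen; no ring) in place of a group of 7 heavy atoms (4 carbon, 2 nitrogen, 1 sulfur; no ring), on a saturated chain carbon, three bonds along the chain from an aromatic nitrogen.

Going by the values given here, two measured steps bear on it. Trading a cyano-bearing tail for a sulfur-bearing one, as in a number 37.9 percentage points higher from compound 1 to compound 2 (beyond the scatter), raised this assay a great deal; yet a number 13.5 percentage points lower from compound 1 to compound 3 (beyond the scatter), a similar trade on a shorter chain, lowered it. Compound 4 moves back toward a cyano-bearing tail on a still shorter chain, so the expectation is a modest rise, a number 10.5 percentage points higher from compound 3 to compound 4 (beyond the scatter), with wide uncertainty. Compound 4 is estimated at 28%, between 5% and 55%.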

Compound 4, a percentage reported as inhibition, in the whole organism at one dose (the size of the read-out at that dose, not a potency): 72.2%
Compound 4: middle estimate off by 44.2 percentage points, on the low side, outside the stated range (above it).
By their numbers in this assay, from the lowest: compound 3; then compound 1; then compounds 2 and 4 (each within the scatter of the next).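

In this assay, a cyano-bearing tail on this saturated chain is not tied to a low number: the step is a number 41.2 percentage points higher from compound 1 to compound 4 (beyond the scatter), and the step from the sulfur-bearing tail is a number 54.7 percentage points higher from compound 3 to compound 4 (beyond the scatter). With a number 3.3 percentage points higher from compound 2 to compound 4 (within the scatter), a tail that holds no sulfur reaches the same level as the sulfur-bearing tail of compound 2, so sulfur is not needed for a high number among these compounds. No measurement shown here explains these steps.

On these data alone, each of these steps changes the tail and the chain together, so the share of each change remains unknown. As far as these compounds go, it also remains open how a thiourea tail on the chain of compound 4, a urea tail or a longer chain would read in this assay.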